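A few compounds are considered here, and "the series" means these few. Any claim that something is new, unique, unknown or untested is made for them only; others in the source may bear on it.

Measured so far in a functional assay on IGROV-1 cells (Homo sapiens) for inhibition, read by sulforhodamine B assay, with a stated time of 48 h (a lower number here means a stronger inhibitor of growth, a higher number a weaker inhibitor of growth), are these compounds:
Compound 1 `O=C(Cc1csc2nc(-c3ccc(Br)cc3)cn12)N/N=C/c1ccccc1` gives 32400 nM in this series
Compound 2 `O=C(Cc1csc2nc(-c3ccc(Br)cc3)cn12)N/N=C/c1ccc(O)cc1` gives 39800 nM in this series
Compound 3 `COc1cccc(OC)c1/C=N/NC(=O)Cc1csc2nc(-c3ccc(Br)cc3)cn12` gives 26900 nM in this series

Compound 3 stands level with the other two: a 1.2-fold lower number from compound 1 to compound 3 (0.08 log units; within the scatter) and a 1.5-fold lower number from compound 2 to compound 3 (0.17 log units; within the scatter) both lie within the scatter. Compound 4 `O=C(Cc1csc2nc(-c3ccc(Br)cc3)cn12)N/N=C/c1ccc(Cl)cc1Cl` differs from compound 3 by 2,4-dichlorophenyl in place of 2,6-dimethoxyphenyl on a carbon with a double bond to nitrogen with 2,4-dichlorophenyl in place of 2,6-dimethoxyphenyl on a carbon with a double bond to nitrogen. The third measured step of a 1.2-fold higher number from compound 1 to compound 2 (0.09 log units; within the scatter) is also within the scatter. None of these steps brings in a 2,4-dichlorophenyl group, so the support is indirect. Even so, no step beyond the scatter and no particular direction is expected in this assay for this change. The expected step is a 1.1-fold higher number from compound 3 to compound 4 (0.05 log units; within the scatter) and remains within the scatter. For compound 4 the estimated value is 30000 nM with 14000 nM to 60000 nM as the expected range.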

Compound 4, concentration for total growth inhibition: 45700 nM
The estimate for compound 4 lay 1.5-fold (0.18 log units) below the measured number; the measured number falls inside the stated range.
By their numbers in this assay, from the lowest: compounds 3, 1, 2 and 4 (each within the scatter of the next).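

In this assay, the 2,4-dichlorophenyl group on a carbon with a double bond to nitrogen leaves compound 4 level with the other three, with a 1.7-fold higher number from compound 3 to compound 4 (0.23 log units; within the scatter) and a 1.1-fold higher number from compound 2 to compound 4 (0.06 log units; within the scatter) and a 1.4-fold higher number from compound 1 to compound 4 (0.15 log units; within the scatter) all within the scatter. This extends the flat picture at this position to a ring carrying chlorine, alongside the phenyl, 4-hydroxyphenyl and 2,6-dimethoxyphenyl groups. No supporting measurement is available to explain this result. As far as these compounds go, whether an amine or a carboxylic acid on this ring would move the number beyond the scatter remains open, as does the effect of a longer chain in its place.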